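Working notes: changing the aryl group on nitrogen

A few compounds are considered here, and "the series" means these few. Any claim that something is new, unique, unknown or untested is made for them only; others in the source may bear on it.

- compound 1 `COc1cc(C(=O)c2cn(-c3ccc(F)cc3)cc2-c2ccco2)cc(OC)c1OC`: 17 nM
- compound 2 `COc1cc(C(=O)c2cn(-c3cccc(C)c3)cc2-c2ccccn2)cc(OC)c1OC`: 140 nM

Both values come from a functional assay on MCF7 cells (Homo sapiens) for inhibition, with a stated time of 96 h; on this read-out lower numbers stand for stronger inhibition and higher numbers for weaker inhibition. Compound 2 holds the higher of the two numbers, beyond the scatter from compound 1. Compound 3 `COc1cc(C(=O)c2cn(-c3ccc(F)cc3)cc2-c2ccccn2)cc(OC)c1OC` has 4-fluorophenyl in place of 3-methylphenyl on an aromatic nitrogen. Only compound 1, at 17 nM, carries 4-fluorophenyl there among the measured compounds, but it also differs from compound 3 elsewhere, so the expectation is tentative. A moderate move toward stronger inhibition is expected, estimated as a 2.5-fold lower number from compound 2 to compound 3 (0.41 log units; beyond the scatter). The estimate for compound 3 is 55 nM, with an expected range of 18 nM to 170 nM.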

Compound 3, half-maximal inhibitory concentration: 73 nM
The estimate for compound 3 lay 1.3-fold (0.12 log units) below the measured number; measured number inside the range.
By their numbers in this assay, from the lowest: compound 1; then compounds 3 and 2 (each within the scatter of the next).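

In this assay, 4-fluorophenyl in place of 3-methylphenyl on the aromatic nitrogen gives a 1.9-fold lower number from compound 2 to compound 3 (0.28 log units; within the scatter) and so does not separate these two aryl groups when pyridin-2-yl is on the core. Pyridin-2-yl in place of furan-2-yl on an aromatic carbon gives a 4.3-fold higher number from compound 1 to compound 3 (0.63 log units; beyond the scatter) and is the only single-place step here beyond the scatter. No measurement offers a reason for either step.

Open, from the compounds shown here alone, is whether an amine or carboxylic acid on the nitrogen's aryl group, or an alkyl chain replacing it, would separate from 4-fluorophenyl. Also open, going by these compounds, is whether the carbon step holds with 3-methylphenyl on the nitrogen.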